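Ethoxy for methoxy, repeated on a second core

The source may report more compounds than this note shows. Statements on the series, on what has been measured and on what is new or still open speak of the compounds shown alone.

Of the compounds shown here, three have been measured in a functional assay on aorta (Rattus norvegicus, strain Wister); on this read-out lower numbers stand for stronger inhibition and higher numbers for weaker inhibition. Compound 1, `COc1nc(-c2nc3ccccc3n2C)cc(-c2ccc(Cl)cc2Cl)c1C#N`, gives 214000 nM. Compound 2, `CCOc1nc(-c2nc3ccccc3n2C)cc(-c2ccc(Cl)cc2Cl)c1C#N`, differs from it by methyl in place of hydrogen on a saturated chain carbon bound to an oxygen on an aromatic ring. In this assay compound 2 gives 305000 nM. The resulting step is a 1.4-fold higher number from compound 1 to compound 2 (0.15 log units; within the scatter). Compound 3, `COc1nc(-c2nc3ccccc3n2C)cc(-c2cccs2)c1C#N`, carries a different group on the shared core; the difference between the two cores is thiophen-2-yl in place of 2,4-dichlorophenyl on an aromatic carbon. In this assay compound 3 gives 312000 nM. That step is a 1.5-fold higher number from compound 1 to compound 3 (0.16 log units; within the scatter).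

Compound 4, `CCOc1nc(-c2nc3ccccc3n2C)cc(-c2cccs2)c1C#N`, has not yet been measured. It differs from compound 3 by methyl in place of hydrogen on a saturated chain carbon bound to an oxygen on an aromatic ring, the same change that leads from compound 1 to compound 2, made at the same place on the core of compound 3. Among the compounds with values here, this change occurs twice among the four compounds, and its one measured instance gave a 1.4-fold higher number from compound 1 to compound 2 (0.15 log units; within the scatter). For compound 4 a step of similar size is expected, a 1.4-fold higher number from compound 3 to compound 4 (0.14 log units; within the scatter). That expectation rests on a single measured pair and so carries the full scatter of the read-out. Compound 4 is therefore estimated to give 430000 nM in this assay, within a range from 200000 nM to 900000 nM.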

Compound 4, half-maximal inhibitory concentration: 249000 nM
The estimate for compound 4 lay 1.7-fold (0.24 log units) above the measured number, within the range that was stated.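

In this assay, methoxy to ethoxy on the core of compound 3 gives a 1.3-fold lower number from compound 3 to compound 4 (0.10 log units; within the scatter), and set beside the same change on the core of compound 1, it shows no difference beyond the scatter: the same change on two cores in this assay, a 1.4-fold higher number (0.15 log units; within the scatter) from compound 1 to compound 2 and a 1.3-fold lower number (0.10 log units; within the scatter) from compound 3 to compound 4, 1.8-fold (0.25 log units) apart, within the scatter of two such steps

Thiophen-2-yl in place of 2,4-dichlorophenyl, now with ethoxy on the core, gives a 1.2-fold lower number from compound 2 to compound 4 (0.09 log units; within the scatter), and this too does not differ from its earlier counterpart beyond the scatter: the same change on two cores in this assay, a 1.5-fold higher number (0.16 log units; within the scatter) from compound 1 to compound 3 and a 1.2-fold lower number (0.09 log units; within the scatter) from compound 2 to compound 4, 1.8-fold (0.25 log units) apart, within the scatter of two such steps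

The two changes can therefore be carried from one core to the other here only in the sense that each stays within the scatter on both; with no step beyond the scatter, this does not show that an effect of any real size or direction transfers between the cores.

The compounds shown leave open whether a longer chain such as propoxy, or an amine, in place of the methoxy would move the number beyond the scatter on either core. They also leave open what a carboxylic acid in place of the nitrile would do.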